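A few compounds are considered here, and "the series" means these few. Any claim that something is new, unique, unknown or untested is made for them only; others in the source may bear on it.

In a functional assay on MCF7 cells (Homo sapiens) for antiproliferative activity, read by CCK-8 assay, with a stated time of 48 h (on this read-out higher numbers stand for weaker inhibition and lower numbers for stronger inhibition), compound 1 `C=CC(=O)NCCOc1ccc(Oc2c(-c3ccc(F)cc3)sc3cc(O)ccc23)cc1` gives 23000 nM, the highest of the two numbers shown, though the gap to its neighbour stays within the scatter. Among the measured compounds shown here, compound 2 `CN(C)C(=O)/C=C/CN1CC(Oc2ccc(Oc3c(-c4ccc(F)cc4)sc4cc(O)ccc34)cc2)C1` gives 22300 nM in this assay, and the single measured step, a 1.0-fold lower number from compound 1 to compound 2 (0.01 log units; within the scatter), replaced the very side chain that changes here. Compound 3 `C=CC(=O)N1CC(Oc2ccc(Oc3c(-c4ccc(F)cc4)sc4cc(O)ccc34)cc2)C1` differs from compound 1 by 1-(vinylcarbonyl)azetidin-3-yl in place of 2-((vinylcarbonyl)amino)ethyl on an oxygen on an aromatic ring. For the measured compounds named here, that step is the only one bearing on the change and moved nothing beyond the scatter, so no shift beyond the scatter is expected in this assay. Compound 3 is thus expected at 22000 nM, between 11000 nM and 45000 nM, a step of a 1.0-fold lower number from compound 1 to compound 3 (0.02 log units; within the scatter).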

Compound 3, half-maximal inhibitory concentration: 23500 nM
For compound 3 the middle estimate is 1.1-fold (0.03 log units) below the measured one; the measured number falls inside the stated range.
By their numbers in this assay, from the lowest: compounds 2, 1 and 3 (each within the scatter of the next).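

In this assay, 1-(vinylcarbonyl)azetidin-3-yl in place of 2-((vinylcarbonyl)amino)ethyl on the oxygen gives a 1.0-fold higher number from compound 1 to compound 3 (0.01 log units; within the scatter), so the four-membered ring and the loss of the hydrogen-bond donor leave the number within the scatter. On the ring amine nitrogen, vinylcarbonyl in place of 3-(dimethylcarbamoyl)prop-2-en-1-yl gives a 1.1-fold higher number from compound 2 to compound 3 (0.02 log units; within the scatter), so this change also stays within the scatter. Nothing available offers a reason for these results. On these data alone, whether a piperidine ring or a longer chain on this oxygen would move the number beyond the scatter remains open. The same holds for a free amine in place of the vinylcarbonyl.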